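Extending the Thioether Chain with a Carboxymethyl Group

The source may report more compounds than this note shows. Statements on the series, on what has been measured and on what is new or still open speak of the compounds shown alone.

Compound 1 `CCCCCC(=O)Nc1cc(-c2ccccc2)c(-c2ccccc2)nn1`: > 300000 nM
Compound 2 `CCCCCCCOc1cc(-c2ccccc2)c(-c2ccccc2)nn1`: 58000 nM
Compound 3 `CCCCCCSc1cc(-c2ccccc2)c(-c2ccccc2)nn1`: 62000 nM

Of the compounds shown here, three sharing one core have been tested in an assay on microsomes from liver for inhibition of sterol O-acyltransferase 1 (Rattus norvegicus); on this read-out lower numbers stand for stronger inhibition and higher numbers for weaker inhibition. For compound 1 the value given is a limit of the assay and not a number, namely (the limit of > 300000 nM in this assay, at which 1 of the 3 values shown sits). Compound 2 gives 58000 nM in this assay, and compound 3 gives 62000 nM. The two steps away from compound 1 are an at least 5.1-fold lower number from compound 1 to compound 2 (0.71 log units; beyond the scatter) and an at least 4.8-fold lower number from compound 1 to compound 3 (0.68 log units; beyond the scatter). Between the two numbered compounds the step is a 1.1-fold higher number from compound 2 to compound 3 (0.03 log units; within the scatter), so compound 3 and compound 2 sit within the scatter of each other; compound 3 holds the higher of the two numbers, but that gap means nothing.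

Compound 4 `O=C(O)CCCCCCCSc1cc(-c2ccccc2)c(-c2ccccc2)nn1` has not yet been measured. It differs from compound 3 in one place: carboxymethyl in place of hydrogen on a saturated chain carbon, six bonds along the chain from a sulfur. Within the data shown here, none of the measured steps touches the far end of the chain; the only steps known concern the group attached to the aromatic carbon, and those two steps were at least modest, while the step between compound 2 and compound 3 lies within the scatter. Among the measured compounds shown here, no measured step therefore bears directly on this change, and the account expects for compound 4 a step of a 1.0-fold lower number from compound 3 to compound 4 (0.01 log units; within the scatter) in this assay, that is, none beyond the scatter. The estimate for compound 4 in this assay is 60000 nM, with a range from 12000 nM to 300000 nM.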

Compound 4, half-maximal inhibitory concentration: > 300000 nM
Compound 4: only a limit was reported; the forecaster's own chance of this, stated with the estimate: 20%; at least 5.0-fold (0.69 log units) between middle value and limit.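

Among these compounds, the far end of the chain proves not to be a silent place in this assay, which the earlier compounds, changed only in the group on the aromatic carbon, could not show: the step is an at least 4.8-fold higher number from compound 3 to compound 4 (0.68 log units; beyond the scatter). Carboxymethyl in place of hydrogen on a saturated chain carbon, six bonds along the chain from a sulfur, therefore weakens inhibition on this read-out, a change of a different kind from the exchange of heptyloxy for hexylsulfanyl, which stayed within the scatter. The value for compound 4 is a limit of the assay and not a number, so the step has a lower bound only and its full size stays unknown: the limit of > 300000 nM in this assay, at which 2 of the 4 values shown sit.

The compounds shown do not separate the carboxylic acid from the added chain length, so it remains open whether a plain longer chain, a methyl ester or an amide at the same chain end would keep the number of compound 3. They also leave open how a carboxylic acid on a shorter chain, or an amine at the chain end, would read.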